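The source may report more compounds than this note shows. Statements on the series, on what has been measured and on what is new or still open speak of the compounds shown alone.

In an ADME assay on J774.A1 cells (Mus musculus) for inhibition, read by MTT assay, with a stated time of 72 h (a lower number here means that less compound is needed, a higher number that more compound is needed for the effect), compound 1 (`CNc1nc(NCc2ccccc2)nc2ccccc12`) gives 15000 nM and compound 2 (`Cc1ccc(CNc2nc(NCc3ccccc3)nc3ccccc23)cc1`) gives 2100 nM. Compound 3 (`Cc1ccccc1-c1nc(NCc2ccccc2)nc2ccccc12`) has no single number, and its result reads "not determined" (no result reported). Compound 4 (`CC(C)Nc1nc(NCc2ccccc2)nc2ccccc12`) carries isopropylamino in place of 2-methylphenyl on an aromatic carbon. Compound 3 offers no starting value, so no step size or direction can be expected from it. Within the data shown here, the only measured step, a 7.1-fold lower number from compound 1 to compound 2 (0.85 log units; beyond the scatter), is modest and changes the group on that same aromatic carbon. Compound 4 also has an amino group there, so its number is expected in or near the span of compound 1 at 15000 nM and compound 2 at 2100 nM. For compound 4 the estimated value is 7000 nM, with an expected range of 2500 nM to 20000 nM.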

Compound 4, half-maximal effective concentration: 7200 nM
For compound 4 the middle estimate is 1.0-fold (0.01 log units) below the measured one; the measured number falls inside the stated range.
By their numbers in this assay, from the lowest: compound 2; then compound 4; then compound 1.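

In this assay the series shows a 2.1-fold lower number from compound 1 to compound 4 (0.32 log units; beyond the scatter) and a 3.4-fold higher number from compound 2 to compound 4 (0.54 log units; beyond the scatter), so isopropyl on this nitrogen sits between methyl and 4-methylbenzyl. The order from highest to lowest number therefore runs methyl, isopropyl, 4-methylbenzyl, a pattern that holds for these three compounds only. No measurement shown here accounts for this order.

On these data alone, whether cyclohexyl or a straight butyl chain on this nitrogen would follow the same order stays open. Among these compounds, compound 3 has no number, so no step to it can be read, and 2-methylphenyl remains unplaced against the amino groups.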